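Carboxy in Place of Trifluoromethyl: Three Measured, One Expected

The source may hold more compounds than are shown below. What is called first, only, known or untested is meant among the compounds shown, and "the series" means these compounds.

Measured compounds:
Compound 1, `Cc1n[nH]c(C(=O)O)c1Cc1ccc(C(F)(F)F)cc1`, 9%
Compound 2, `Cc1n[nH]c(C(=O)O)c1Cc1cccc(C(F)(F)F)c1`, 5%
Compound 3, `Cc1n[nH]c(C(=O)O)c1Cc1ccc(C(=O)O)cc1`, 3%

In an assay on isolated protein for inhibition of 2-Hydroxyacid oxidase 2 (Homo sapiens), tested at 1 uM (a higher number here means a stronger effect of the compound at the concentration tested, a lower number a weaker effect), compound 1 gives 9%, compound 2 gives 5% and compound 3 gives 3%; all three numbers sit within the scatter of one another. Compound 1 and compound 3 differ by carboxy in place of trifluoromethyl on an aromatic carbon, and the step of a number 6 percentage points lower from compound 1 to compound 3 (within the scatter) is within the scatter. Compound 1 and compound 2 have the same atoms joined differently; the difference between the two cores is not broken down here.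

Compound 4, `Cc1n[nH]c(C(=O)O)c1Cc1cccc(C(=O)O)c1`, has not been measured. It differs from compound 2 by carboxy in place of trifluoromethyl on an aromatic carbon. This is the same kind of change as that from compound 1 to compound 3, but the place differs: meta to a large group in compound 4, para to a large group in compound 3. The step of a number 3 percentage points lower from compound 2 to compound 4 (within the scatter) is expected to be small, because a number 6 percentage points lower from compound 1 to compound 3 (within the scatter) was within the scatter. Compound 4 is therefore estimated at 2% in this assay, between -8% and 12%.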

Compound 4, a percentage reported as inhibition, at one concentration (the size of the read-out at that concentration, not a potency): 3%
The estimate for compound 4 lay 1 percentage points below the measured number; low and high end bracket the measured number.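

In this assay, carboxy in place of trifluoromethyl on an aromatic carbon gives a number 2 percentage points lower from compound 2 to compound 4 (within the scatter). Set beside the earlier step, the change reads alike on the two cores: the same change on two cores in this assay, a number 6 percentage points lower (within the scatter) from compound 1 to compound 3 and a number 2 percentage points lower (within the scatter) from compound 2 to compound 4, 4 percentage points apart, within the scatter of two such steps

Within the data shown here, neither step lies beyond the scatter, so the series shows only that the change, on these two cores, produced no step that can be told from repeated measurement at one concentration; it does not show that the change has no effect, or that the same would hold on a core with a larger read-out.

The compounds shown leave open what an amine, an amide or a nitrile in place of trifluoromethyl would give in this assay. They also leave open whether a longer chain in place of the methyl on the shared core would change the read-out.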